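Butyl Carbamate to Allyl Carbamate on a Shared Core

The compounds below may be only part of what the source reports. "The series", "measured", "known", "first", "only" and "open" are said of these compounds alone.

Compound 1 `CCCCNC(=O)OC/C=C(\C)C1=CC(=O)C(C)(C)O1` was tested in a functional assay on FM3A cells (Mus musculus) for inhibition (on this read-out higher numbers stand for weaker inhibition and lower numbers for stronger inhibition), where compound 1 gives 7.7 ug/mL. Two further compounds share its core. In this assay compound 2 `C/C(=C\C=C/C1CCCCC1)C1=CC(=O)C(C)(C)O1` gives 10.8 ug/mL, and compound 3 `C/C(=C\C=C\c1ccccc1)C1=CC(=O)C(C)(C)O1` gives 15 ug/mL. Compound 1 has the lowest of the three numbers, but its gaps to compound 2 and to compound 3 both lie within the scatter, so no order among them can be read from these values.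

Compound 4 `C=CCNC(=O)OC/C=C(\C)C1=CC(=O)C(C)(C)O1` differs from compound 1 in one place: vinyl in place of propyl on a saturated chain carbon bound to an amide-type nitrogen. Among the measured compounds shown here, no measured pair shows a step of this kind. The change is small, and the expected step in this assay is a 1.0-fold higher number from compound 1 to compound 4 (0.02 log units; within the scatter), not beyond the scatter in either direction. Compound 4 is therefore estimated at 8 ug/mL, with a range from 4 ug/mL to 16 ug/mL.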

Compound 4, half-maximal inhibitory concentration: 7.6 ug/mL
Estimate against measurement, compound 4: 1.1-fold (0.02 log units) above; the measured number falls inside the stated range.
By their numbers in this assay, from the lowest: compounds 4, 1, 2 and 3 (each within the scatter of the next).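

In this assay, among the compounds shown here, the step from propyl to vinyl on a saturated chain carbon bound to an amide-type nitrogen gives a 1.0-fold lower number from compound 1 to compound 4 (0.01 log units; within the scatter) and thus supplies the first direct comparison at this position. Replacing butyl with allyl on the carbamate nitrogen leaves no difference that can be told from scatter. Nothing available explains this match.

From the compounds shown here alone, whether a longer chain, a phenyl ring or an amine at the end of this chain would move the number beyond the scatter remains open.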